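Swapping the Ester Aryl Group on a Shared Core

The compounds below may be only part of what the source reports. "The series", "measured", "known", "first", "only" and "open" are said of these compounds alone.

Compound 1 `COc1ccc(C(=O)OCC2Oc3ccc([C@H]4Oc5cc(O)cc(O)c5C(=O)[C@@H]4O)cc3OC2c2ccc(O)c(OC)c2)cc1` is one of three close relatives tested in a functional assay on liver (Rattus norvegicus, strain Sprague-Dawley) for inhibition, with a stated time of 1 h (on this read-out higher numbers stand for weaker inhibition and lower numbers for stronger inhibition), where compound 1 gives 21000 nM. Compound 2 `COc1cc(C2Oc3cc([C@H]4Oc5cc(O)cc(O)c5C(=O)[C@@H]4O)ccc3OC2COC(=O)c2ccc(N)cc2)ccc1O` gives 14300 nM and compound 3 `COc1cc(C2Oc3cc([C@H]4Oc5cc(O)cc(O)c5C(=O)[C@@H]4O)ccc3OC2COC(=O)c2ccccc2)ccc1O` gives 12700 nM. Compound 1 shows the highest of the three numbers, yet the step of a 1.5-fold lower number from compound 1 to compound 2 (0.17 log units; within the scatter) and the step of a 1.7-fold lower number from compound 1 to compound 3 (0.22 log units; within the scatter) both stay within the scatter, as does a 1.1-fold lower number from compound 2 to compound 3 (0.05 log units; within the scatter); on these data the three compounds cannot be told apart.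

Compound 4 `COc1cc(C2Oc3cc([C@H]4Oc5cc(O)cc(O)c5C(=O)[C@@H]4O)ccc3OC2COC(=O)/C=C/c2ccc(Br)cc2)ccc1O` has not been measured. It differs from compound 1 at the carbonyl carbon: 2-(4-bromophenyl)ethenyl in place of 4-methoxyphenyl on a carbonyl carbon. The three measured steps all alter a group on an aromatic carbon of the 4-methoxyphenyl, and none of them moved the numbers beyond the scatter. The change to compound 4 is larger, exchanging the whole 4-methoxyphenyl for a 2-(4-bromophenyl)ethenyl, and nothing measured covers such an exchange, so the range must stay wide. The step of a 1.4-fold lower number from compound 1 to compound 4 (0.15 log units; within the scatter) is therefore expected to be small, with no change beyond the scatter. In this assay compound 4 is estimated at 15000 nM, between 6000 nM and 40000 nM.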

Compound 4, half-maximal inhibitory concentration: 16300 nM
Beside the measured number, compound 4's estimate is 1.1-fold (0.04 log units) below it; the measured number falls inside the stated range.
By their numbers in this assay, from the lowest: compounds 3, 2, 4 and 1 (each within the scatter of the next).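

In this assay, the whole group on the carbonyl carbon can be exchanged, not only a substituent on its ring, and the number still does not shift: 2-(4-bromophenyl)ethenyl in place of 4-methoxyphenyl gives a 1.3-fold lower number from compound 1 to compound 4 (0.11 log units; within the scatter), in place of phenyl it gives a 1.3-fold higher number from compound 3 to compound 4 (0.11 log units; within the scatter), and in place of 4-aminophenyl it gives a 1.1-fold higher number from compound 2 to compound 4 (0.06 log units; within the scatter). So, across these four compounds, this position takes a double bond outside the aromatic ring and a bromine with no change beyond the scatter, whereas the earlier steps only varied what sat on the ring itself. Nothing available explains this flat result.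

For the compounds shown here, every group at this position so far contains a six-membered aromatic ring of carbon, so it remains open whether a plain alkyl chain, a carboxylic acid or a saturated amine in its place would also leave the number unchanged. The ethenyl link and the bromine also arrive together in compound 4, and only a 2-phenylethenyl or a 4-bromophenyl group on the carbonyl carbon would separate the two.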